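The compounds below may be only part of what the source reports. "The series", "measured", "known", "first", "only" and "open" are said of these compounds alone.

Of the compounds shown here, three sharing one core have been measured so far in a functional assay on HCT-116 cells (Homo sapiens) for inhibition, read by MTT assay, with a stated time of 2 days, tested at 100 uM; a lower number here means less inhibition of growth, a higher number more inhibition of growth at the concentration tested. Compound 1 `CNC(=O)c1cc(Oc2ccc3nc(NC(=O)c4ccc(Cl)cc4Cl)sc3c2)ccn1` gives 64.4%, the lowest of the three numbers. Compound 2 `CNC(=O)c1cc(Oc2ccc3nc(NC(=O)c4ccc(Cl)cc4)sc3c2)ccn1` gives 80.5%, and compound 3 `CNC(=O)c1cc(Oc2ccc3nc(NC(=O)Nc4ccc(C5CCN(C(C)C)CC5)cc4)sc3c2)ccn1` gives 95.5%. Among the compounds with values here, the only pair that differs in a single place is compound 1 and compound 2, where a number 16.1 percentage points higher from compound 1 to compound 2 (beyond the scatter), a hydrogen in place of chloro on an aromatic carbon.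

Compound 4 `CNC(=O)c1cc(Oc2ccc3nc(NC(=O)c4cccc(F)n4)sc3c2)ccn1` has not yet been measured. It differs from compound 1 by 6-fluoropyridin-2-yl in place of 2,4-dichlorophenyl on a carbonyl carbon. Within the data shown here, the one measured step that bears on this is a number 16.1 percentage points higher from compound 1 to compound 2 (beyond the scatter), which removed a single chloro from the same ring and was followed by a modest rise in growth inhibition. Since the new ring carries no chloro at all, a step of similar size and in the same direction is expected, a number 13.6 percentage points higher from compound 1 to compound 4 (beyond the scatter), though the exchange of the whole ring leaves this uncertain. Compound 4 is therefore expected to give about 78%, within a range from 60% to 93%.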

Compound 4, percent growth inhibition at one concentration: 55.5%
Compound 4: the middle estimate sits 22.5 percentage points above what was measured; the measured number lies below the stated range.
By their numbers in this assay, from the lowest: compounds 4 and 1 (each within the scatter of the next); then compound 2; then compound 3.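

In this assay, the whole ring on the carbonyl carbon can be exchanged: 6-fluoropyridin-2-yl in place of 2,4-dichlorophenyl gives a number 8.9 percentage points lower from compound 1 to compound 4 (within the scatter), so these two groups cannot be told apart here. The same group in place of 4-chlorophenyl gives a number 25 percentage points lower from compound 2 to compound 4 (beyond the scatter), which shows that a ring without chloro does not always go with more growth inhibition at this position, and that the earlier gain seen on removing one chloro does not carry over to this new ring. No measurement at hand explains this difference.

As far as these compounds go, it remains open which part of the new ring matters, the ring nitrogen or the fluorine; an unsubstituted pyridin-2-yl on the same carbonyl would help to separate the two. Also open, from the compounds shown here alone, is how a ring bearing an amine or a methoxy group would read at this position.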